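Replacing 5-(trifluoromethyl)pyridin-2-yl with 4-methylphenyl on a sulfur

The source may report more compounds than this note shows. Statements on the series, on what has been measured and on what is new or still open speak of the compounds shown alone.

Compound 1 `COc1ccc(SCc2ccc(/C=C/C(=O)Nc3ccccc3N)cc2)cc1OC` gives 65.5%
Compound 2 `CCc1ccc(SCc2ccc(/C=C/C(=O)Nc3ccccc3N)cc2)cc1` gives 60.7%
Compound 3 `Nc1ccccc1NC(=O)/C=C/c1ccc(CSc2ccc(C(F)(F)F)cn2)cc1` gives 51.7%

All three numbers come from a functional assay on A549 cells (Homo sapiens) for inhibition, read by CCK-8 assay, with a stated time of 72 h, tested at 2 uM (a higher number here means more inhibition of growth at the concentration tested, a lower number less inhibition of growth), and compound 4 `Cc1ccc(SCc2ccc(/C=C/C(=O)Nc3ccccc3N)cc2)cc1` has not yet been measured there. Compound 3 sits clearly under compound 1, as the step of a number 13.8 percentage points lower from compound 1 to compound 3 (beyond the scatter) shows. It cannot be told apart from compound 2, as the step of a number 9 percentage points lower from compound 2 to compound 3 (within the scatter) shows.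

Compound 4 puts 4-methylphenyl in place of 5-(trifluoromethyl)pyridin-2-yl on a sulfur, and the count of that change is 4-methylphenyl in place of 5-(trifluoromethyl)pyridin-2-yl on a sulfur in full. The nearest measured match is the 4-ethylphenyl of compound 2, so the step into compound 3 from that side is the best guide, read in reverse. The step of a number 4.8 percentage points lower from compound 1 to compound 2 (within the scatter) adds that compound 1 and compound 2 also stay close together. The expected move is a number 8.3 percentage points higher from compound 3 to compound 4 (within the scatter) upward, which would be small. For compound 4 the estimated value is 60% with an expected range from 50% to 70% in this measurement.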

Compound 4, percent growth inhibition at one concentration: 43.4%
Beside the measured number, compound 4's estimate is 16.6 percentage points above it; measured number outside the range, below it.
By their numbers in this assay, from the lowest: compounds 4, 3, 2 and 1 (each within the scatter of the next, the first and the last beyond it).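

Putting hydrogen in place of methyl on the saturated chain carbon, which turns 4-ethylphenyl into 4-methylphenyl, gives a number 17.3 percentage points lower from compound 2 to compound 4 (beyond the scatter) in this assay, so this position responds to an edit much smaller than the whole-ring swaps seen earlier. Replacing the 3,4-dimethoxyphenyl on the sulfur with 4-methylphenyl gives a number 22.1 percentage points lower from compound 1 to compound 4 (beyond the scatter), whereas the change of 5-(trifluoromethyl)pyridin-2-yl to 4-methylphenyl gives a number 8.3 percentage points lower from compound 3 to compound 4 (within the scatter), so those two quite different groups cannot be told apart here. No measurement available here explains why a small change on the ring counts for more than a change of the ring itself. From the compounds shown here alone, whether a longer chain than ethyl would keep the number near that of the ethyl compound remains open. So does the outcome with an amine or a carboxylic acid on the same ring.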